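Stability series: aryl replacements para to the benzamide

The source may hold more compounds than are shown below. What is called first, only, known or untested is meant among the compounds shown, and "the series" means these compounds.

Measured compounds in an ADME assay on microsomes from liver (Rattus norvegicus, strain Sprague-Dawley) for metabolic stability, read by HPLC, using NADPH, with stated times of 5 min and 60 min, tested at 10 uM; on this read-out higher numbers stand for a longer-lived compound and lower numbers for a shorter-lived compound:
compound 1 `CC(C)(C)c1ccc(C(=O)NCc2ccc(NS(=O)(=O)C(F)(F)F)cc2Cl)cc1` gives 1.3 h;
compound 2 `CS(=O)(=O)Nc1ccc(CNC(=O)c2ccc(C34CC(C3)C4)cc2)c(Cl)c1` gives 1.35 h;
compound 3 `CC(C)(O)c1ccc(C(=O)NCc2ccc(NS(C)(=O)=O)cc2Cl)cc1` gives 20.2 h.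

Compound 2 stands second highest of the three; compound 1 is within the scatter of it, and compound 3 lies well above it.

Compound 4 `CS(=O)(=O)Nc1ccc(CNC(=O)c2ccc(CC(F)(F)F)cc2)c(Cl)c1` differs from compound 2 by a group of 5 heavy atoms (2 carbon, 3 fluorine; no ring) in place of a group of 5 heavy atoms (5 carbon; 2 four-membered non-aromatic rings of carbon only), on an aromatic carbon.

Within the data shown here, the only measured step at this position is a 15-fold higher number from compound 2 to compound 3 (1.18 log units; beyond the scatter), a large gain, but the entering group there carried an oxygen and lacked a ring, whereas 2,2,2-trifluoroethyl carries neither donor nor acceptor. Among the measured compounds shown here, no measured step copies this exchange. A modest rise beyond the scatter is expected, given the direction of a 15-fold higher number from compound 2 to compound 3 (1.18 log units; beyond the scatter), but much smaller than that step. For compound 4 in this assay the estimate is 2.5 h (range 0.9 h to 8 h), which is expected to mean a step of a 1.9-fold higher number from compound 2 to compound 4 (0.27 log units; within the scatter).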

Compound 4, half-life: 1.03 h
Compound 4: the middle estimate sits 2.4-fold (0.39 log units) above what was measured; measured number inside the range.
By their numbers in this assay, from the lowest: compounds 4, 1 and 2 (each within the scatter of the next); then compound 3.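

In this assay the step of a 1.3-fold lower number from compound 2 to compound 4 (0.12 log units; within the scatter) shows that replacing the two-ring group with the ring-free 2,2,2-trifluoroethyl leaves the half-life within the scatter, so losing the rings alone does not reproduce the gain seen with compound 3. Among these compounds, the step of a 20-fold lower number from compound 3 to compound 4 (1.29 log units; beyond the scatter) shows that the large gap also holds against a second ring-free group, leaving 1-hydroxy-1-methylethyl as the only group here with a long half-life. Nothing available explains this difference.

Going by these compounds, it remains open whether the hydroxyl itself carries the gain. A methoxy or aminomethyl group on this aromatic carbon would test how specific it is.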